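The source may report more compounds than this note shows. Statements on the series, on what has been measured and on what is new or still open speak of the compounds shown alone.

Working notes on a small set of triketone inhibitors sharing one core.

Compound 1 `O=C1CCCC(=O)C1C(=O)COc1ccc(Cl)cc1` carries a chloro on the aryl ether ring; in an assay for inhibition of 4-hydroxyphenylpyruvate dioxygenase (Arabidopsis thaliana), with a stated time of 10 min (a higher number here means a weaker inhibitor, a lower number a stronger inhibitor), compound 1 gives 31 nM. Compound 2 `O=C1CCCC(=O)C1C(=O)COc1ccccc1Cl` moves the chloro to a different aromatic carbon, and in this assay compound 2 gives 31 nM. On the numbers shown, compound 2 stands level with compound 1 at the digits printed, its nearest neighbour, with no change beyond the scatter; the two values say nothing about an order between them.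

Compound 3 `Cc1ccccc1OCC(=O)C1C(=O)CCCC1=O` has not yet been measured in this assay. The change from compound 2 to compound 3 is methyl in place of chloro on an aromatic carbon. Among the measured compounds shown here, no step between two measured compounds that differ in one place is recorded here, so nothing in the measured pair speaks to this swap directly. The two chloro isomers both sit at the same inhibition constant, which suggests the aryl substituent pattern tolerates small variation. The step is expected to be small, a 1.5-fold higher number from compound 2 to compound 3 (0.16 log units; within the scatter), likely within the scatter or at most slightly weaker. Compound 3 is therefore estimated at 45 nM, with a range from 18 nM to 110 nM.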

Compound 3, inhibition constant: 31 nM
Compound 3: the middle estimate sits 1.5-fold (0.16 log units) above what was measured; the measured number falls inside the stated range.
By their numbers in this assay, from the lowest: compounds 1, 2 and 3 (each within the scatter of the next).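

In this assay, methyl in place of chloro on an aromatic carbon, ortho to a large group, gives no change at the digits printed from compound 2 to compound 3 (within the scatter). Compound 1 and compound 2 showed only that the chloro could sit on two different aromatic carbons with the same printed value, whereas this step replaces the substituent itself: at this position, one chlorine atom gives way to one carbon atom with no readable change in the inhibition constant. The presence of chlorine at this position is therefore not required to retain the printed value of compound 2, and no measurement available here bears on why the value holds across this swap.

The chloro and methyl groups each count one heavy atom, with no ring, no hydrogen-bond donor or acceptor and no net charge, so the compounds shown do not tell how far this position tolerates larger or different groups. On these data alone, an amine, a carboxylic acid, a methoxy group or a longer chain such as propyl at this position remains open, as does methyl on the aromatic carbon that holds the chloro in compound 1.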